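Cytotoxicity at the chain terminus: acid to amide

The compounds below may be only part of what the source reports. "The series", "measured", "known", "first", "only" and "open" are said of these compounds alone.

Three compounds of the series share one core and differ only in the group at the end of the saturated chain on the aromatic nitrogen. Compound 1 is `N=C(CCCn1c(Cn2c(=O)n(C3CC3)c3ccncc32)cc2cc(Cl)ccc21)NO`; in an ADME assay on HeLa cells (Homo sapiens) for cytotoxicity, read by ATP content, with a stated time of 3 days (a higher number here means that more compound is tolerated, a lower number that less compound is tolerated), compound 1 reaches only the limit > 50000 nM. Compound 2 is `O=c1n(Cc2cc3cc(Cl)ccc3n2CCCCO)c2cnccc2n1C1CC1`; in this assay compound 2 likewise gives the limit > 50000 nM. Compound 3 is `O=C(O)CCCn1c(Cn2c(=O)n(C3CC3)c3ccncc32)cc2cc(Cl)ccc21`; in this assay compound 3 also stops at the limit > 50000 nM. Compound 3 therefore stands at the limit, together with the other two values, none of which is a number.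

The steps between the measured compounds are accordingly unreadable: a step that the two limits leave unreadable from compound 1 to compound 2, a step that the two limits leave unreadable from compound 1 to compound 3 and a step that the two limits leave unreadable from compound 2 to compound 3. All three sit at the limit of > 50000 nM in this assay, at which 3 of the 3 values shown sit.

Compound 4 is `NC(=O)CCCn1c(Cn2c(=O)n(C3CC3)c3ccncc32)cc2cc(Cl)ccc21`; it differs from compound 3 by amino in place of hydroxy on a carbonyl carbon. Within the data shown here, the step that bears most directly on it is the one from compound 2 to compound 3, a change at the same chain terminus, yet it too is unreadable. Among the measured compounds shown here, no measured step gives a direction, so no step beyond the scatter is expected in this assay, and the estimated step that the limit leaves unreadable from compound 3 to compound 4 is set near zero. Compound 4 is therefore expected to give about 60000 nM, between 25000 nM and 200000 nM, most likely again reported as a limit.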

Compound 4, half-maximal cytotoxic concentration: > 50000 nM
Compound 4 ended at the assay's limit; the forecaster's own chance of this, stated with the estimate: 85%; the middle value is on the limit's open side.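

Compound 4 stops at a limit in this assay, as compound 1, compound 2 and compound 3 do, so no step from any of them to compound 4 can be read: the limit of > 50000 nM in this assay, at which 4 of the 4 values shown sit.

The compounds shown leave open whether any change at the chain terminus alters cytotoxicity, and how far the four true values lie beyond the limit.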